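The source may hold more compounds than are shown below. What is called first, only, known or untested is meant among the compounds shown, and "the series" means these compounds.

Working notes on the sulfonamide series.

Three compounds have numbers in a functional assay on Umbilical vein for antagonist activity at B1 bradykinin receptor (Homo sapiens), using Schild analysis, with a stated time of 30 min; on this read-out lower numbers stand for lower potency and higher numbers for higher potency (the scale is a negative logarithm). Compound 1 `COc1ccc(S(=O)(=O)N(C)CCOCC(=O)N(C)Cc2ccc(C3=NCCN3)cc2)c(C)c1` gives 8.6 in this assay. Compound 2 `COc1cc(C)c(S(=O)(=O)N(C)CCOCC(=O)N2CCC(C3CCN(C(C)C)CC3)CC2)c(C)c1` gives 9.3 in this assay, and compound 3 `COc1cc(C)c(S(=O)(=O)N(C)CCOCC(=O)N2CCN(CCN(C)C)CC2)c(C)c1` gives 7.4 in this assay. Compound 1 thus stands second of the three: compound 2 sits higher by a margin beyond the scatter, and compound 3 sits lower by a larger margin, also beyond the scatter. No pair among these three differs in a single place, so no isolated step is available within the measured set.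

Compound 4 `Cc1c(Cl)cccc1S(=O)(=O)N(C)CCOCC(=O)N(C)Cc1ccc(C2=NCCN2)cc1` is not yet measured. It differs from compound 1 in one place: 3-chloro-2-methylphenyl in place of 4-methoxy-2-methylphenyl on a sulfonyl sulfur

The measured compounds offer no direct guide to a change of this kind, so the expectation rests on compound 1 alone. A small step, if any, is expected from compound 1 to compound 4 in this assay, a number 0.20 log units lower from compound 1 to compound 4 (within the scatter), with a slight lean toward the lower side. Compound 4 is expected to give about 8.4 in this assay, within a range from 7.6 to 9.1.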

Compound 4, negative logarithm of the antagonist equilibrium constant: 8
Beside the measured number, compound 4's estimate is 0.40 log units above it; the measured number falls inside the stated range.
By their numbers in this assay, from the lowest: compound 3; then compound 4; then compound 1; then compound 2.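

In this assay, the group on the sulfonyl sulfur now has its first isolated change: 3-chloro-2-methylphenyl in place of 4-methoxy-2-methylphenyl gives a number 0.60 log units lower from compound 1 to compound 4 (beyond the scatter). The position is therefore not indifferent to this exchange, although the step is modest and compound 4 still gives 8 on the core of compound 1. No measurement at hand bears on the reason for the drop, and the step stands as an observation only.

As far as these compounds go, the methoxy group leaves and the chlorine enters in the same step, and their separate contributions remain open. A plain 2-methylphenyl group on the sulfonyl sulfur, carrying neither methoxy nor chlorine, would separate the two contributions on this core.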